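Working notes: compound 4 against its three measured neighbours

This account rests on a few compounds, and the source may have more. Where it says the series, first, only, none or still open, it means among the compounds named here.

Measured so far in a functional assay on MCF7 cells (Homo sapiens) for inhibition, read by MTT assay, with a stated time of 48 h; on this read-out higher numbers stand for weaker inhibition and lower numbers for stronger inhibition:
compound 1, `CCOC(=O)C1=C(N/C=N/c2cccnc2Cl)Nc2[nH]nc(C)c2C1c1ccc(N(C)C)cc1`: 4180 nM
compound 2, `CCOC(=O)C1=C(N/N=C(/C#N)C(=O)OCC)Nc2[nH]nc(C)c2C1c1ccc(N(C)C)cc1`: 35600 nM
compound 3, `CCOC(=O)C1=C(N/N=C(/C(=O)Br)c2ccc(Br)cc2)Nc2[nH]nc(C)c2C1c1ccc(N(C)C)cc1`: 61300 nM

Compound 1 stands at the lowest number of the three; the step of an 8.5-fold higher number from compound 1 to compound 2 (0.93 log units; beyond the scatter) and the step of a 15-fold higher number from compound 1 to compound 3 (1.17 log units; beyond the scatter) both lie beyond the scatter, so compound 1 is the strongest inhibitor of the measured set. Compound 2 and compound 3 differ from each other by a 1.7-fold higher number from compound 2 to compound 3 (0.24 log units; within the scatter), within the scatter.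

Compound 4, `CCOC(=O)C(=NNC1=C(C(=O)OCC)C(c2ccc(N(C)C)cc2)c2c(C)n[nH]c2N1)C(=O)OCC`, differs from compound 1 as follows: a group of 12 heavy atoms (7 carbon, 1 nitrogen, 4 oxygen; no ring) in place of a group of 9 heavy atoms (6 carbon, 2 nitrogen, 1 chlorine; one six-membered aromatic ring with 1 hetero atom), on an amine nitrogen. The group that enters in compound 4 has no ring and is attached through the same amine nitrogen as the group that enters in compound 2, which also has no ring and carries an ester; the step of an 8.5-fold higher number from compound 1 to compound 2 (0.93 log units; beyond the scatter) therefore bears most directly on it. The step of a 15-fold higher number from compound 1 to compound 3 (1.17 log units; beyond the scatter) runs in the same direction. Every replacement of the ring-bearing group of compound 1 measured here has raised the number, so a rise beyond the scatter is expected for compound 4, with a 9.6-fold higher number from compound 1 to compound 4 (0.98 log units; beyond the scatter) as the estimated step. The expected value for compound 4 in this assay is 40000 nM, with a range from 14000 nM to 110000 nM.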

Compound 4, half-maximal inhibitory concentration: 89800 nM
Estimate against measurement, compound 4: 2.2-fold (0.35 log units) below; the measured number falls inside the stated range.
By their numbers in this assay, from the lowest: compound 1; then compounds 2, 3 and 4 (each within the scatter of the next, the first and the last beyond it).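

Replacing the ring-bearing group of compound 1 with the ring-free group of compound 4 gives a large step in this assay (a 21-fold higher number from compound 1 to compound 4 (1.33 log units; beyond the scatter)), and the two ring-free groups are not interchangeable on this amine nitrogen: a second ester in place of the nitrile of compound 2 also gives a step beyond the scatter (a 2.5-fold higher number from compound 2 to compound 4 (0.40 log units; beyond the scatter)). The absence of a ring does not separate compound 4 from the bromine-bearing aromatic group of compound 3 (a 1.5-fold higher number from compound 3 to compound 4 (0.17 log units; within the scatter)), a step within the scatter. No measurement is available that accounts for these steps.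

As far as these compounds go, it remains open whether the lower number of compound 1 goes with the chlorine, the ring nitrogen or the rest of its group. A phenyl group without chlorine on this amine nitrogen, or a carboxylic acid in place of an ester of compound 4, would address what this position tolerates.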